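The source may report more compounds than this note shows. Statements on the series, on what has been measured and on what is new or still open speak of the compounds shown alone.

Working notes on the series. Within the data shown here, in an ADME assay on MT4 cells (Homo sapiens) for cytotoxicity, read by MTT assay, with a stated time of 4 days (on this read-out higher numbers stand for lower toxicity in this test and lower numbers for higher toxicity in this test), compound 1 `CNC(=O)Nc1c(C)c(C(OC(C)(C)C)C(=O)O)c(-c2ccc(C)c(C)c2)c(C)c1-c1ccc(C)c(C)c1` gives 20000 nM and compound 2 `Cc1ccc(-c2c(C)c(-c3ccc(C)c(C)c3)c(C(OC(C)(C)C)C(=O)O)c(C)c2NC(=O)c2ccccc2)cc1C` gives 9100 nM, the lowest of the two numbers so far. Among the measured compounds shown here, the only measured step, with phenyl in place of methylamino on a carbonyl carbon, is a 2.2-fold lower number from compound 1 to compound 2 (0.34 log units; beyond the scatter). It is modest but beyond the scatter.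

Compound 3 `CCC(=O)Nc1c(C)c(C(OC(C)(C)C)C(=O)O)c(-c2ccc(C)c(C)c2)c(C)c1-c1ccc(C)c(C)c1` has not yet been measured in this assay. Its difference from compound 2 is ethyl in place of phenyl on a carbonyl carbon, or benzamido to propanoylamino. For the measured compounds named here, this change also removes the phenyl, so the single measured step bears on it, although methylamino and ethyl are different groups and one step makes no pattern. Compound 1, without that phenyl, stands at 20000 nM, so a modest move to a higher number is expected, no larger than the measured step and possibly within the scatter. The estimated step is a 1.6-fold higher number from compound 2 to compound 3 (0.22 log units; within the scatter). For compound 3 the expected value is 15000 nM, with an estimated range of 8000 nM to 28000 nM.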

Compound 3, half-maximal cytotoxic concentration: 15000 nM
Beside the measured number, compound 3's estimate shows no gap at the digits printed; low and high end bracket the measured number.
By their numbers in this assay, from the lowest: compounds 2, 3 and 1 (each within the scatter of the next, the first and the last beyond it).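

In this assay, the two steps that bring ethyl onto this carbonyl carbon both stay within the scatter: ethyl in place of phenyl gives a 1.6-fold higher number from compound 2 to compound 3 (0.22 log units; within the scatter), and ethyl in place of methylamino gives a 1.3-fold lower number from compound 1 to compound 3 (0.12 log units; within the scatter). Among these compounds, the single earlier step, a 2.2-fold lower number from compound 1 to compound 2 (0.34 log units; beyond the scatter), showed only that two groups at this place could be told apart, whereas the propanoylamino compound now shows that the six-membered aromatic ring can leave, with the benzamido changed to propanoylamino, without a step distinguishable from repeat measurement, and that the only separated pair in this short set remains the two compounds on either side of it. Nothing measured here gives a reason for these small differences.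

With one value for each of three groups, no trend with the size or kind of group on this carbonyl carbon can be drawn. From the compounds shown here alone, whether a longer chain such as butyl, a dimethylamino group, a pyridine ring or a substituted phenyl at this place would stay in the same range remains open.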